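The compounds below may be only part of what the source reports. "The series", "measured", "known", "first", "only" and "open" are said of these compounds alone.

Working notes on the series. The shared core carries a chloro-substituted bicyclic sulfonyl group on a six-membered lactam ring, and the compounds differ only in the bicyclic heteroaromatic group on the saturated chain carbon bound to the amide-type nitrogen in that ring. Compound 1 `O=C1CN(S(=O)(=O)c2cc3ccc(Cl)cc3s2)CCN1Cc1cc2c[nH]ccc-2n1` is one such variant. In an assay on isolated protein for binding affinity to serine protease 1 (Homo sapiens) (on this read-out higher numbers stand for weaker inhibition and lower numbers for stronger inhibition), compound 1 gives only a limit, > 2900 nM. Compound 2 `O=C1CN(S(=O)(=O)c2cc3ccc(Cl)cc3s2)CCN1Cc1cc2[nH]cccc-2n1` carries an isomeric bicycle. In this assay compound 2 likewise gives only a limit, > 2900 nM. Compound 3 `O=C1CN(S(=O)(=O)c2cc3ccc(Cl)cc3s2)CCN1Cc1nc2cc[nH]cc-2n1` is the third variant. In this assay compound 3 again gives only a limit, > 2900 nM. The steps a step that the two limits leave unreadable from compound 1 to compound 2, a step that the two limits leave unreadable from compound 1 to compound 3 and a step that the two limits leave unreadable from compound 2 to compound 3 cannot be read, since (the limit of > 2900 nM in this assay, at which 3 of the 3 values shown sit).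

Compound 4 `O=C1CN(S(=O)(=O)c2cc3ccc(Cl)cc3s2)CCN1Cc1cc2cnccc2o1` is not yet measured. It differs from compound 3 by a group of 9 heavy atoms (7 carbon, 1 nitrogen, 1 oxygen; one five-membered aromatic ring with 1 hetero atom, one six-membered aromatic ring with 1 hetero atom) in place of a group of 9 heavy atoms (6 carbon, 3 nitrogen; one five-membered aromatic ring with 2 hetero atoms, one six-membered aromatic ring with 1 hetero atom), on a saturated chain carbon bound to an amide-type nitrogen in a ring. Among the compounds with values here, none of the measured steps is readable, so no direction or size is known for this change; the only evidence is that all three neighbouring compounds sit at the limit. The expectation for compound 4 is therefore a weak value at or near that limit, an expected step that the limit leaves unreadable from compound 3 to compound 4 from compound 3. Compound 4 is expected to give 5000 nM in this assay, within a range from 1500 nM to 20000 nM.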

Compound 4, inhibition constant in the serine protease 1 assay: > 2900 nM
Compound 4: only a limit was reported; the forecaster's own chance of this, stated with the estimate: 70%; the middle value lies beyond the limit too.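

Within the data shown here, the steps from compound 1, compound 2 and compound 3 to compound 4 in the serine protease 1 assay cannot be read, so the result for compound 4 gives no new step: the limit of > 2900 nM in the serine protease 1 assay, at which 4 of the 4 values shown sit. In the serine protease 1 assay compound 4 gives only a limit, > 2900 nM.

In a physicochemical assay, compound 3 gives 6.1. In the physicochemical assay compound 4 gives 5.8. These two values lie within the usual scatter of each other.

The compounds shown leave open whether any of these four groups gives a measurable inhibition constant in the serine protease 1 assay and how far they differ from one another.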